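Urea Anilines on a Shared Core: Astrocyte Cytotoxicity

The source may report more compounds than this note shows. Statements on the series, on what has been measured and on what is new or still open speak of the compounds shown alone.

Measured so far:
compound 1 `O=C(Nc1cccc(F)c1)Nc1cc2ncncc2cc1OCc1cccc(Cl)c1` gives > 10000 nM
compound 2 `O=C(Nc1ccccc1F)Nc1cc2ncncc2cc1OCc1cccc(F)c1` gives > 10000 nM
compound 3 `O=C(Nc1cccc(Cl)c1)Nc1cc2ncncc2cc1OCc1ccccc1` gives 7400 nM

In an ADME assay on cells (Astrocyte, Homo sapiens) for cytotoxicity, read by WST assay, with a stated time of 72 h (on this read-out lower numbers stand for stronger inhibition and higher numbers for weaker inhibition), compound 1 reaches only a limit, > 10000 nM, and not a number. Compound 2 also sits at a limit, > 10000 nM. Compound 3 gives a number, 7400 nM. So compound 1 stands among the weakest readings shown, at the top of what this assay reports.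

Compound 4 `O=C(Nc1ccc(C(F)(F)F)cc1)Nc1cc2ncncc2cc1OCc1cccc(Cl)c1` differs from compound 1 in one place: 4-(trifluoromethyl)phenyl in place of 3-fluorophenyl on an amide-type nitrogen. Among the measured compounds shown here, no measured pair of compounds shares this change, so its size is unknown. Because (the limit of > 10000 nM in this assay, at which 2 of the 3 values shown sit), the step from compound 1 to compound 4 is expected to stay small, likely within the scatter, with no clear direction. Compound 4 is thus expected to give about 12000 nM, roughly between 5000 nM and 30000 nM, meaning an expected step that the limit leaves unreadable from compound 1 to compound 4.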

Compound 4, half-maximal inhibitory concentration: 8800 nM
For compound 4 the middle estimate is 1.4-fold (0.13 log units) above the measured one; the measured number falls inside the stated range.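

In this assay, putting 4-(trifluoromethyl)phenyl in place of 3-fluorophenyl on an amide-type nitrogen gives an at least 1.1-fold lower number from compound 1 to compound 4 (0.05 log units; that floor lies within the scatter). Among the compounds shown here, this is the first reading on this position that can be set against compound 1, and it shows only that the larger group gives a number rather than a limit. How far the step really reaches cannot be read, because one end of it is a limit: the limit of > 10000 nM in this assay, at which 2 of the 4 values shown sit.

As far as these compounds go, whether the step goes beyond the scatter stays open. So does what an amine or a carboxylic acid on this phenyl ring would do to the reading.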